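The source may report more compounds than this note shows. Statements on the series, on what has been measured and on what is new or still open speak of the compounds shown alone.

Measured compounds in a physicochemical assay for solubility, in phosphate buffer, measured as kinetic solubility, at pH 7.2; a lower number here means a less soluble compound, a higher number a more soluble compound:
- compound 1 `COC(=O)N[C@H](C(=O)N1CCC[C@H]1C(=O)Nc1ccc([C@@H]2CC[C@@H](c3ccc(NC(=O)[C@@H]4CCCN4C(=O)[C@@H](NC(=O)OC)C(C)C)cc3)N2c2ccc(F)cc2)cc1)C(C)C` gives 4100 nM
- compound 2 `COC(=O)N[C@H](C(=O)N1CCC[C@H]1C(=O)Nc1ccc([C@@H]2CC[C@@H](c3ccc(NC(=O)[C@@H]4CCCN4C(=O)[C@@H](NC(=O)OC)[C@H]4CCOC4)cc3)N2c2ccc(F)cc2)cc1)[C@H]1CCOC1` gives 9700 nM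
- compound 3 `COC(=O)N[C@H](C(=O)N1CCC[C@H]1C(=O)Nc1ccc([C@@H]2CC[C@@H](c3ccc(NC(=O)[C@@H]4CCCN4C(=O)[C@@H](NC(=O)OC)C(C)(C)C)cc3)N2c2ccc(F)cc2)cc1)C(C)(C)C` gives 4400 nM

Compound 3 holds the second highest of the three numbers. Its nearest neighbour is compound 1, which sits within the scatter of it, while compound 2 lies furthest away, beyond the scatter. Compound 4 `COC(=O)N[C@H](C(=O)N1CCC[C@H]1C(=O)Nc1ccc([C@H]2CC[C@H](c3ccc(NC(=O)[C@@H]4CCCN4C(=O)[C@@H](NC(=O)OC)C(C)(C)C)cc3)N2c2ccc(F)cc2)cc1)C(C)(C)C` is built from compound 3 as follows: the two compounds have the same atoms and bonds and differ only in configuration as drawn: 2 of 6 stereo elements differ; a stereocentre at a saturated ring carbon is drawn S in compound 3 and R in compound 4; a stereocentre at a saturated ring carbon is drawn S in compound 3 and R in compound 4. Among the measured compounds shown here, no measured pair shows a step of this kind, so the expectation rests on the two compounds sharing every atom and bond. A change of configuration alone is expected to shift the number little, and the step from compound 3 to compound 4 is estimated at no change at the digits printed from compound 3 to compound 4 (within the scatter), no larger than the scatter. Compound 4 is therefore expected to give 4400 nM, within a range of 2000 nM to 9500 nM.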

Compound 4, solubility: 3900 nM
The estimate for compound 4 lay 1.1-fold (0.05 log units) above the measured number; low and high end bracket the measured number.
By their numbers in this assay, from the lowest: compounds 4, 1 and 3 (each within the scatter of the next); then compound 2.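

In this assay, among the compounds shown here, the pair gives the first view of a change in configuration at these saturated ring carbons, with both drawn S in one compound and R in the other, and the outcome is a 1.1-fold lower number from compound 3 to compound 4 (0.05 log units; within the scatter). At this position, then, the inversion of both stereocentres together leaves no difference that can be told from the scatter. This comparison isolates configuration from every other structural change: the fact that compounds 3 and 4 differ only in the configuration as drawn

Inverting only one of the two ring carbons remains open. So does whether the same inversion would count as little in a compound carrying an amine or a carboxylic acid.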